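The source may hold more compounds than are shown below. What is called first, only, known or untested is meant among the compounds shown, and "the series" means these compounds.

Working notes on the series. In an ADME assay on microsomes from liver (Mus musculus) for metabolic stability, read by LC-MS, using NADPH, with a stated time of 60 min, tested at 0.1 uM (on this read-out lower numbers stand for a less stable compound and higher numbers for a more stable compound), compound 1 `O=C(c1ccnc(Nc2nc3cnc(Nc4ccc(F)c(C(F)(F)F)c4)cc3[nH]2)c1)N1CCN(C2CC2)CC1` gives 93%, compound 2 `C[C@@H]1CN(C(=O)c2ccnc(Nc3nc4cnc(Nc5ccc(F)c(C(F)(F)F)c5)cc4[nH]3)c2)C[C@H](C)N1` gives 90% and compound 3 `C[C@@H]1CN(C(=O)c2ccnc(Nc3nc4cnc(Nc5ccc(F)c(C(F)(F)F)c5)cc4[nH]3)c2)C[C@H](C)O1` gives 41%. Compound 2 therefore stands level with compound 1, with a number 3 percentage points lower from compound 1 to compound 2 (within the scatter), and well clear of compound 3, with a number 49 percentage points lower from compound 2 to compound 3 (beyond the scatter).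

Compound 4 `C[C@@H]1CN(C(=O)c2ccnc(Nc3nc4cnc(Nc5cccc(C(F)(F)F)c5)cc4[nH]3)c2)C[C@H](C)N1` keeps the amide of compound 2 and differs at the other end of the molecule: hydrogen in place of fluoro on an aromatic carbon. This is hydrogen in place of fluoro on an aromatic carbon, ortho to a trifluoromethyl group and para to a large group.

Among the compounds with values here, no measured step touches this place. All three steps, including a number 52 percentage points lower from compound 1 to compound 3 (beyond the scatter), lie at the group on the carbonyl carbon, so they bear on this change only indirectly and give no size for it. With no evidence for a shift, no step beyond the scatter is expected in this assay, though the uncertainty is wide, mostly towards lower numbers.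

The expected step is a number 4 percentage points lower from compound 2 to compound 4 (within the scatter). For compound 4 the estimated value is 86%, with an expected range of 68% to 97%.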

Compound 4, percent of the compound remaining: 86%
Beside the measured number, compound 4's estimate shows no gap at the digits printed, within the range that was stated.
By their numbers in this assay, from the lowest: compound 3; then compounds 4, 2 and 1 (each within the scatter of the next).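

In this assay, within the data shown here, the step of a number 4 percentage points lower from compound 2 to compound 4 (within the scatter) is the first reading at this end of the molecule, and it shows that the fluoro on the aromatic carbon, ortho to a trifluoromethyl group and para to a large group, can give way to hydrogen with no shift beyond the scatter. Among these compounds, with the 3,5-dimethylpiperazin-1-yl amide in place, the read-out therefore does not depend on this fluoro, whereas the earlier steps beyond the scatter all lie at the group on the carbonyl carbon. No measurement available here accounts for this result.

Still open, as far as these compounds go, is whether the same change would be as quiet with the 2,6-dimethylmorpholin-4-yl amide of compound 3. Equally open, from the compounds shown here alone, is how this carbon would respond to a larger group, such as chloro, methoxy or a nitrile, in place of the hydrogen.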